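Benzyl substituent swap at the shared core

This account rests on a few compounds, and the source may have more. Where it says the series, first, only, none or still open, it means among the compounds named here.

Measured so far:
compound 1 `Cc1cc(Nc2nc(NCc3ccc(C#N)cc3)nc3ccccc23)n[nH]1`: 83 nM
compound 2 `Cc1cc(Nc2nc(NCc3ccc(OC(F)(F)F)cc3)nc3ccccc23)n[nH]1`: 4100 nM

In an assay for inhibition of high affinity nerve growth factor receptor (Homo sapiens), read by HTRF, with a stated time of 30 min, in the presence of a further agent that is not named here (a higher number here means a weaker inhibitor, a lower number a stronger inhibitor), compound 1 holds the lower of the two numbers. Going by the values given here, the single measured step, a 49-fold higher number from compound 1 to compound 2 (1.69 log units; beyond the scatter), is large and beyond the scatter. Compound 3 `Cc1cc(Nc2nc(NCc3ccc(F)cc3F)nc3ccccc23)n[nH]1` carries 2,4-difluorophenyl in place of 4-cyanophenyl on a saturated chain carbon bound to a nitrogen on an aromatic ring. Among the compounds with values here, that step bears on it only in part, since the entering group differs from the one in compound 2, so the size is uncertain; a weakening is expected, and the step is estimated as an 11-fold higher number from compound 1 to compound 3 (1.04 log units; beyond the scatter). For compound 3 the expected value in this assay is 900 nM, with a range from 200 nM to 4000 nM.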

Compound 3, half-maximal inhibitory concentration: 200 nM
The estimate for compound 3 lay 4.5-fold (0.65 log units) above the measured number; low and high end bracket the measured number.
By their numbers in this assay, from the lowest: compound 1; then compound 3; then compound 2.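

In this assay the nitrile is not needed for a low number at this position: 2,4-difluorophenyl in place of 4-cyanophenyl gives only a 2.4-fold higher number from compound 1 to compound 3 (0.38 log units; beyond the scatter) and this step is modest though beyond the scatter. Replacing 4-cyanophenyl therefore need not cost as much as in compound 2 at 4100 nM on this core. No available evidence accounts for the difference between these replacements. The compounds shown leave open whether a single fluorine would give the same number as the pair in compound 3. From the compounds shown here alone, how an amine, a carboxylic acid or a longer chain would read on this aromatic ring also remains open.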